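The source may hold more compounds than are shown below. What is called first, only, known or untested is meant among the compounds shown, and "the series" means these compounds.

Four anilides built on two related cores were compared for their ability to slow the growth of cultured cells. Compound 1 `COc1ccc(NC(=O)COc2ccc3c(=O)cc(-c4ccccc4)oc3c2)cc1` and compound 2 `O=C(COc1ccc2c(=O)cc(-c3ccccc3)oc2c1)Nc1ccc(-c2ccccc2)cc1` share one core; compound 3 `COc1ccc(NC(=O)COc2ccc3c(=O)c(-c4ccccc4)coc3c2)cc1` and compound 4 `O=C(COc1ccc2c(=O)c(-c3ccccc3)coc2c1)Nc1ccc(-c2ccccc2)cc1` share another. Compound 3 has the same atoms as compound 1, joined differently, and the difference between the two cores is not broken down here.

In a functional assay on MT2 cells (Homo sapiens) for antiproliferative activity, read by MTT assay, with a stated time of 72 h (a higher number here means a weaker inhibitor of growth, a lower number a stronger inhibitor of growth), compound 1 gives 6700 nM, and compound 2 gives 2480 nM. The change between them, (phenyl in place of methoxy on an aromatic carbon), produced a step of a 2.7-fold lower number from compound 1 to compound 2 (0.43 log units; beyond the scatter). Compound 3 gives 4550 nM in this assay, a value within the scatter of compound 1 and of compound 2.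

Compound 4 differs from compound 3 by phenyl in place of methoxy on an aromatic carbon, the same change as that from compound 1 to compound 2, with the same surroundings. Compound 4 is expected to show a step of a 2.6-fold lower number from compound 3 to compound 4 (0.41 log units; beyond the scatter) in this assay, because the same change gave a 2.7-fold lower number from compound 1 to compound 2 (0.43 log units; beyond the scatter). Compound 4 is therefore estimated at 1750 nM, with a likely range from 750 nM to 4200 nM.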

Compound 4, concentration for 50% growth inhibition: > 10000 nM
Compound 4 ended at the assay's limit; the forecaster's own chance of this, stated with the estimate: 3%; middle value at least 5.7-fold (0.75 log units) from the limit.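

In this assay compound 4 gives > 10000 nM, which is a limit of the assay and not a number. Even with that limit, phenyl in place of methoxy on an aromatic carbon gives an at least 2.1-fold higher number from compound 3 to compound 4 (0.34 log units; beyond the scatter), opposite in direction to the step on the core of compound 1, so in these two pairs the change did not carry from one core to the other: the same change on two cores in this assay, a 2.7-fold lower number (0.43 log units; beyond the scatter) from compound 1 to compound 2 and an at least 2.1-fold higher number (0.34 log units; beyond the scatter) from compound 3 to compound 4, at least 5.9-fold (0.77 log units) apart, beyond the scatter of two such steps This does not show how far compound 4 lies past the limit or why the two cores part ways, and it rests on a single pair on each core, with the size of the gap known only as a lower bound: the limit of > 10000 nM in this assay, at which 1 of the 4 values shown sits.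

The compounds shown leave open whether another group at the same place, such as a chlorine atom, a methyl group or a carboxylic acid, would follow the step on the core of compound 1 or the one on the core of compound 3. Also open, going by these compounds, is whether a longer chain between the core and the amide would alter the gap between the two steps.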